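Replacing 2,4,5-Trichlorophenyl with 4-Methoxyphenyl

The source may report more compounds than this note shows. Statements on the series, on what has been measured and on what is new or still open speak of the compounds shown alone.

Values in a functional assay on HL-60 cells (Homo sapiens) for antiproliferative activity, read by MTT assay, with a stated time of 72 h; a higher number here means a weaker inhibitor, a lower number a stronger inhibitor:
- compound 1 `NC1=NC2(CCSCC2)N(OCCCOc2ccc(Cl)c(Cl)c2)C(N)=N1`: 140 nM
- compound 2 `NC1=NC2(CCSCC2)N(OCCCOc2cc(Cl)c(Cl)cc2Cl)C(N)=N1`: 730 nM

Compound 2 has the higher of these two numbers, which makes it the weaker inhibitor of the pair. Compound 3 `COc1ccc(OCCCON2C(N)=NC(N)=NC23CCSCC3)cc1` differs from it by one change: 4-methoxyphenyl in place of 2,4,5-trichlorophenyl on an oxygen on a saturated carbon. Going by the values given here, only one measured step bears on this change: a 5.2-fold higher number from compound 1 to compound 2 (0.72 log units; beyond the scatter). There, chloro in place of hydrogen on an aromatic carbon gave a modest rise, beyond the scatter. Compound 3 has no chloro on its aromatic ring, so that step, read in reverse, points towards a lower number. However, no measured compound carries 4-methoxyphenyl, which makes this a loose guide. A modest fall is therefore expected in this assay. The expected size is a 2.1-fold lower number from compound 2 to compound 3 (0.32 log units; beyond the scatter). The estimate for compound 3 is 350 nM, with an expected range of 100 nM to 1200 nM.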

Compound 3, half-maximal inhibitory concentration: 500 nM
Compound 3: the middle estimate sits 1.4-fold (0.15 log units) below what was measured; measured number inside the range.
By their numbers in this assay, from the lowest: compound 1; then compounds 3 and 2 (each within the scatter of the next).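

In this assay, 4-methoxyphenyl in place of 2,4,5-trichlorophenyl gives a 1.5-fold lower number from compound 2 to compound 3 (0.16 log units; within the scatter) and so leaves compounds 2 and 3 indistinguishable, which shows that this position tolerates an aromatic ring with no chloro and a methoxy group instead. The same group in place of 3,4-dichlorophenyl gives a clearer difference (a 3.6-fold higher number from compound 1 to compound 3 (0.55 log units; beyond the scatter)) and so does not match compound 1. Of the three aromatic groups at this position, only the 3,4-dichlorophenyl of compound 1 stands apart from both others.

Nothing available explains these differences. From the compounds shown here alone, it remains open whether a single chloro, as in 4-chlorophenyl, would match compound 1, and whether an amine on the ring or a longer chain before the ring would be tolerated.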